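This account rests on a few compounds, and the source may have more. Where it says the series, first, only, none or still open, it means among the compounds named here.

Measured compounds in a physicochemical assay for lipophilicity; a higher number here means a more lipophilic compound, a lower number a more polar compound: compound 1 `CCC(C)OC(=O)/C=C(C)/C=C/CC(C)CCCC(C)C`, 7.69; compound 2 `CCC(C)OC(=O)/C=C(C)/C=C/CC(C)CCCC(C)(C)OC`, 6.49; compound 3 `CCOC(=O)/C=C(C)/C=C/CC(C)CCCC(C)(C)SC`, 6.36.

Compound 1 gives the highest number of the three, both of the other steps from it being beyond the scatter. Its nearest neighbour is compound 2: a number 1.20 log units lower from compound 1 to compound 2 (beyond the scatter), a large step for a single change, methoxy in place of hydrogen on a saturated chain carbon bound to three saturated chain carbons. Compound 3 differs from compound 1 in two places at once, so its value is simply noted as the lowest of the three, somewhat below that of compound 2.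

Compound 4 `C=CCNC(=O)/C=C(C)/C=C/CC(C)CCCC(C)C` is to be measured in this assay. It differs from compound 1 at the carbonyl carbon: allylamino in place of sec-butoxy on a carbonyl carbon. Among the measured compounds shown here, no measured step covers an exchange at this position; the step from compound 1 to compound 2 only shows how far a single change can move the number. The entering allylamino group carries a hydrogen-bond donor where the leaving sec-butoxy carried an acceptor, and it is the smaller group. A downward step beyond the scatter is therefore expected. The expected step is a number 1.39 log units lower from compound 1 to compound 4 (beyond the scatter). Compound 4 is estimated at 6.3, within a range of 5.5 to 7.1.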

Compound 4, partition coefficient: 5.23
The estimate for compound 4 lay 1.07 log units above the measured number; the whole stated range lies above it.
By their numbers in this assay, from the lowest: compound 4; then compounds 3 and 2 (each within the scatter of the next); then compound 1.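

In this assay, the carbonyl carbon proves to be a position where a single exchange moves the number strongly: a number 2.46 log units lower from compound 1 to compound 4 (beyond the scatter). This step is larger than the other single change in the series, a number 1.20 log units lower from compound 1 to compound 2 (beyond the scatter), so the chain end is not the only place where the number responds, and it is not the place of the largest listed step. The exchange of sec-butoxycarbonyl for allylcarbamoyl alters several things at once, including the heteroatom bound to the carbonyl carbon, the heavy-atom count, the hydrogen-bond donor count and the presence of a double bond, and no measurement shown bears on why the number falls so far.

The compounds shown do not separate these features: sec-butylamino would keep the carbon count of the leaving group, propylamino would replace the allyl chain with a saturated one, and dimethylamino would carry no amide hydrogen. Also open, from the compounds shown here alone, is whether allylamino gives a step of similar size on the methoxy-bearing chain of compound 2.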